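From a 4-methoxyphenyl to a hydroxy on the shared core

A few compounds are considered here, and "the series" means these few. Any claim that something is new, unique, unknown or untested is made for them only; others in the source may bear on it.

In an assay for binding affinity to Neuronal acetylcholine receptor; alpha4/beta2 (Rattus norvegicus) (a higher number here means a weaker inhibitor, a lower number a stronger inhibitor), compound 1 `COc1ccc(-c2cnc3cc4c(cc3n2)C2CNCC4C2)cc1` gives 26 nM, the highest of the three numbers measured. Compound 3 `Cc1cnc2cc3c(cc2c1)C1CNCC3C1` gives 0.65 nM, a lower number beyond the scatter, and compound 2 `Clc1ccc2cc3c(cc2n1)C1CNCC3C1` gives 0.27 nM, the lowest of the three and again beyond the scatter. Compound 4 `Oc1cnc2cc3c(cc2n1)C1CNCC3C1` has not been measured; it differs from compound 1 by hydroxy in place of 4-methoxyphenyl on an aromatic carbon. Among the measured compounds shown here, no measured pair shares this change. Compounds 2 and 3, carrying small groups on their cores, give far lower numbers than compound 1 with its 4-methoxyphenyl, so a drop in the number is expected, though their cores differ from that of compound 1. The step is expected to be an 8.7-fold lower number from compound 1 to compound 4 (0.94 log units; beyond the scatter). Compound 4 is estimated at 3 nM, with a range from 0.5 nM to 20 nM.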

Compound 4, inhibition constant: < 6 nM
Compound 4: no number, only a limit; the forecaster's own chance of this, stated with the estimate: 5%; the middle value does not contradict the limit.
By their numbers in this assay, from the lowest: compound 2; then compound 3; then compound 1.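

In this assay compound 4 gives < 6 nM, which is a limit of the assay and not a number. Hydroxy in place of 4-methoxyphenyl on this aromatic carbon gives an at least 4.3-fold lower number from compound 1 to compound 4 (0.63 log units; beyond the scatter), a step that none of the earlier compounds offered. It shows that the 4-methoxyphenyl is not needed at this position for a lower number, and the step rests on a limit: the limit of < 6 nM in this assay, at which 1 of the 4 values shown sits.

From the compounds shown here alone, how far the number of compound 4 lies under that limit stays open. Also open, going by these compounds, is how an amine or a carboxylic acid on this same aromatic carbon would compare with hydroxy.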